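Replacing 4-hydroxy-3,5-dimethylphenyl in compound 3

The source may report more compounds than this note shows. Statements on the series, on what has been measured and on what is new or still open speak of the compounds shown alone.

Compound 1 `CCC1=C(O)c2c(oc(-c3cc(C)c(C)cc3C)cc2=O)C(CC)(CC)C1=O`: 4.37 uM
Compound 2 `CCC1=C(O)c2c(oc(-c3ccc(OC)c(C)c3C)cc2=O)C(CC)(CC)C1=O`: 0.28 uM
Compound 3 `CCC1=C(O)c2c(oc(-c3cc(C)c(O)c(C)c3)cc2=O)C(CC)(CC)C1=O`: 8.9 uM

These three compounds share one core and differ in the aryl group it carries. All were tested in a functional assay on KBVIN cells (Homo sapiens) for antiproliferative activity, read by sulforhodamine B assay, with a stated time of 3 days; on this read-out lower numbers stand for an effect already at smaller amounts and higher numbers for an effect only at larger amounts of compound. Compound 3 has the highest number of the three, and both other compounds lie beyond the scatter below it, with compound 1 the nearer and compound 2 the further.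

The next compound is compound 4 `CCC1=C(O)c2c(oc(-c3cccc(C)c3C)cc2=O)C(CC)(CC)C1=O`, in which 2,3-dimethylphenyl takes the place of 4-hydroxy-3,5-dimethylphenyl on an aromatic carbon next to the ring oxygen: 2,3-dimethylphenyl in place of 4-hydroxy-3,5-dimethylphenyl on an aromatic carbon.

Among the measured compounds shown here, only one measured step bears directly on this exchange: a 2.0-fold higher number from compound 1 to compound 3 (0.31 log units; beyond the scatter). It is modest, and it also removes a group with no hydroxy in favour of one with it, so it points towards a lower number for compound 4. A further hint comes from compound 2, at 0.28 uM, whose aryl group is the closest measured match to 2,3-dimethylphenyl, with a methoxy group added. On this basis, a step larger than the modest one is expected in this assay, downward, and the estimated change is a 4.9-fold lower number from compound 3 to compound 4 (0.69 log units; beyond the scatter). For compound 4 the expected value is 1.8 uM, with an estimated range from 0.4 uM to 7 uM.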

Compound 4, concentration for half-maximal effect: 0.85 uM
Estimate against measurement, compound 4: 2.1-fold (0.33 log units) above; the measured number falls inside the stated range.
By their numbers in this assay, from the lowest: compound 2; then compound 4; then compound 1; then compound 3.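

In this assay this position proves able to carry a much bigger change than the earlier step showed: the exchange of 4-hydroxy-3,5-dimethylphenyl for 2,3-dimethylphenyl gives a 10-fold lower number from compound 3 to compound 4 (1.02 log units; beyond the scatter), a large step, where a 2.0-fold higher number from compound 1 to compound 3 (0.31 log units; beyond the scatter) was only modest. Loss of the hydroxy group cannot by itself set the number, since compound 1 also has no hydroxy group and still gives a 5.1-fold lower number from compound 1 to compound 4 (0.71 log units; beyond the scatter). The methoxy group of compound 2 also counts, for taking it away gives a 3.0-fold higher number from compound 2 to compound 4 (0.48 log units; beyond the scatter), so the 2,3-dimethylphenyl group already brings a low number without it, and the methoxy group lowers that number further. No measurement at hand accounts for any of these steps.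

Compound 3 and compound 4 differ both in the hydroxy group and in how the methyl groups are placed on the aryl ring, so the share of each in the large step stays unresolved. Going by these compounds, it also stays open whether the gain from methoxy would hold for an ethoxy group, an amine or a carboxylic acid on the same aryl ring.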